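Aryl versus carbamate substituents on the piperidine nitrogen

This account rests on a few compounds, and the source may have more. Where it says the series, first, only, none or still open, it means among the compounds named here.

Measured so far in a functional assay on HEK293 cells for agonist activity at Glucose-dependent insulinotropic receptor (Homo sapiens), read by cAMP accumulation, with a stated time of 60 min; a lower number here means that less compound is needed, a higher number that more compound is needed for the effect:
- compound 1 `CCCS(=O)(=O)N1CC=C(c2ccc3c(c2)CC(C2CCN(C(=O)OC(C)C)CC2)O3)CC1` gives 103 nM
- compound 2 `CCCS(=O)(=O)N1CC=C(c2ccc3c(c2)CC(C2CCN(C(=O)OC4CCCCC4)CC2)O3)CC1` gives 51 nM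
- compound 3 `CCCS(=O)(=O)N1CC=C(c2ccc3c(c2)CC(C2CCN(c4ncc(Cl)cn4)CC2)O3)CC1` gives 78 nM

Compound 2 carries the lowest of the three numbers in this assay; against compound 3 the gap lies within the scatter, against compound 1 it is a 2.0-fold lower number from compound 1 to compound 2 (0.31 log units; beyond the scatter). Compound 4 `CCCS(=O)(=O)N1CC=C(c2ccc3c(c2)CC(C2CCN(c4ccc(C(F)(F)F)cn4)CC2)O3)CC1` differs from compound 2 by 5-(trifluoromethyl)pyridin-2-yl in place of cyclohexyloxycarbonyl on an amine nitrogen in a ring. The step that bears most directly on this change is a 1.5-fold higher number from compound 2 to compound 3 (0.18 log units; within the scatter), where a six-membered aromatic ring with hetero atoms likewise replaced the cyclohexyloxycarbonyl group on the same nitrogen; a 1.3-fold lower number from compound 1 to compound 3 (0.12 log units; within the scatter) points the same way. For compound 4 a step of about a 1.4-fold higher number from compound 2 to compound 4 (0.14 log units; within the scatter) is therefore expected, within the scatter and without a clear direction. The estimate for compound 4 is 70 nM, in the range 30 nM to 160 nM.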

Compound 4, half-maximal effective concentration: 34 nM
Compound 4: the middle estimate sits 2.1-fold (0.31 log units) above what was measured; measured number inside the range.
By their numbers in this assay, from the lowest: compounds 4, 2, 3 and 1 (each within the scatter of the next, the first and the last beyond it).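

At the amine nitrogen in a ring, the two aromatic substituents now separate in this assay (a 2.3-fold lower number from compound 3 to compound 4 (0.36 log units; beyond the scatter)), whereas compound 3 stayed within the scatter of compound 1 and of compound 2. The 5-(trifluoromethyl)pyridin-2-yl group also stands clear of isopropoxycarbonyl (a 3.0-fold lower number from compound 1 to compound 4 (0.48 log units; beyond the scatter)), but not of cyclohexyloxycarbonyl (a 1.5-fold lower number from compound 2 to compound 4 (0.18 log units; within the scatter)). No measurement on hand accounts for these differences.

Ring and substituent change together from compound 3 to compound 4, so their separate contributions remain open. A 5-chloropyridin-2-yl group would separate the two.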